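Fluoro to chloro on compound 1

The source may hold more compounds than are shown below. What is called first, only, known or untested is meant among the compounds shown, and "the series" means these compounds.

In a functional assay on HCT-116 cells (Homo sapiens), read by sulforhodamine B assay, with a stated time of 5 days (a lower number here means a stronger inhibitor of growth, a higher number a weaker inhibitor of growth), compound 1 `OC[C@H]1O[C@@H](n2cc(F)c3c(-c4ccco4)ncnc32)[C@H](O)[C@@H]1O` gives 39 nM, the lowest of the three measured numbers. Compound 2 `OC[C@H]1O[C@@H](n2cc(F)c3c(-c4ccsc4)ncnc32)[C@H](O)[C@@H]1O` gives 140 nM and compound 3 `OC[C@H]1O[C@@H](n2cc(F)c3c(-c4cc[nH]c4)ncnc32)[C@H](O)[C@@H]1O` gives 250 nM, two values within the scatter of each other. Compound 4 `OC[C@H]1O[C@@H](n2cc(Cl)c3c(-c4ccco4)ncnc32)[C@H](O)[C@@H]1O` is unmeasured and differs from compound 1 by chloro in place of fluoro on an aromatic carbon.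

Going by the values given here, no measured step changes the fluoro. The nearest guides are a 3.6-fold higher number from compound 1 to compound 2 (0.56 log units; beyond the scatter) and a 6.4-fold higher number from compound 1 to compound 3 (0.81 log units; beyond the scatter), both replacing furan-2-yl, and a 1.8-fold higher number from compound 2 to compound 3 (0.25 log units; within the scatter). They suggest only a rough size for a single change. In this assay, the expected result is a small rise, a 1.4-fold higher number from compound 1 to compound 4 (0.15 log units; within the scatter), possibly within the scatter. Compound 4 is estimated at 55 nM, with an expected range of 18 nM to 170 nM.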

Compound 4, concentration for 50% growth inhibition: > 10000 nM
Compound 4: only a limit was reported (the forecaster's own chance of this, stated with the estimate: 2%); middle value at least 180-fold (2.25 log units) away from the limit.
By their numbers in this assay, from the lowest: compound 1; then compounds 2 and 3 (each within the scatter of the next). At a limit, above all of these: compound 4.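

In this assay, going by these compounds alone, chloro in place of fluoro on an aromatic carbon of the five-membered aromatic ring gives an at least 250-fold higher number from compound 1 to compound 4 (2.40 log units; beyond the scatter), a far larger step than any seen among the earlier compounds, which all carry fluoro and differ only in the group replacing furan-2-yl. This position is therefore highly sensitive, since exchanging one heavy atom for another, with no change in hydrogen-bond donors, acceptors or net charge, is enough. Compound 4 stands at a limit, not at a number: the limit of > 10000 nM in this assay, at which 1 of the 4 values shown sits.

The compounds shown leave open whether hydrogen, methyl or a nitrile at this position would keep the number of compound 1. They also leave open whether chloro has a similar effect with thiophen-3-yl or 1H-pyrrol-3-yl in place of furan-2-yl.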